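A few compounds are considered here, and "the series" means these few. Any claim that something is new, unique, unknown or untested is made for them only; others in the source may bear on it.

In a functional assay on NCI-H3122 cells (Homo sapiens) for antiproliferative activity, read by MTT assay, with a stated time of 48 h (on this read-out higher numbers stand for weaker inhibition and lower numbers for stronger inhibition), compound 2 `Cc1ccc(CNC(=O)c2cccc(C(C)Oc3ccnc(Nc4cnn(C5CCN(C)CC5)c4)c3)c2)cc1` gives 8900 nM, compound 3 `CC(Oc1ccnc(Nc2cnn(C3CCN(C)CC3)c2)c1)c1cccc(C(=O)NCc2ccc(Cl)c(C(F)(F)F)c2)c1` gives 8000 nM, and compound 1 `Cc1ccc(CNC(=O)c2cccc(C(C)Oc3cccnc3Nc3nncs3)c2)cc1` gives 20800 nM. The numbers for compound 2 and compound 3 lie within the scatter of each other, while the number for compound 1 is higher than that of compound 2, beyond the scatter.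

Compound 4 `Cc1ccc(CNC(=O)c2cccc(C(C)Oc3ccnc(NN4CCN(C)CC4)c3)c2)cc1` departs from compound 2 in one place: 4-methylpiperazin-1-yl in place of 1-(1-methylpiperidin-4-yl)-1H-pyrazol-4-yl on a nitrogen on an aromatic ring. A 4-methylpiperazin-1-yl thus stands in place of the 1-(1-methylpiperidin-4-yl)-1H-pyrazol-4-yl on a nitrogen on an aromatic ring.

Going by the values given here, no measured step covers this exchange. Among the compounds with values here, the only step available, a 1.1-fold lower number from compound 2 to compound 3 (0.05 log units; within the scatter), lies within the scatter and concerns another place, where 4-chloro-3-(trifluoromethyl)phenyl replaces 4-methylphenyl. It shows only that this series held still under that one change. Compound 1 differs from compound 2 in more than one place, so it offers no clean comparison, although compound 1 with 20800 nM suggests how far the numbers can move upward.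

Within the data shown here, with so little to go on, only a small upward drift is expected, with no step clearly beyond the scatter, and the uncertainty is wide. The expected change is a 1.3-fold higher number from compound 2 to compound 4 (0.13 log units; within the scatter). For compound 4 the estimated value in this assay is 12000 nM, with an expected range from 4500 nM to 32000 nM.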

Compound 4, half-maximal inhibitory concentration: 8100 nM
For compound 4 the middle estimate is 1.5-fold (0.17 log units) above the measured one, within the range that was stated.
By their numbers in this assay, from the lowest: compounds 3, 4 and 2 (each within the scatter of the next); then compound 1.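

This is the first step shown at the place on a nitrogen on an aromatic ring; the only earlier step concerned the 4-methylphenyl group elsewhere in the molecule. In this assay the exchange of 1-(1-methylpiperidin-4-yl)-1H-pyrazol-4-yl, with 12 heavy atoms and a five-membered aromatic ring, for 4-methylpiperazin-1-yl, with 7 heavy atoms and no aromatic ring, gives a 1.1-fold lower number from compound 2 to compound 4 (0.04 log units; within the scatter) and so does not separate the two groups. For this pair, then, the five-membered aromatic ring and the five further heavy atoms can go without the number moving beyond the scatter, and nothing available bears on the reason.

The compounds shown leave open how this place responds to other groups, such as morpholin-4-yl, a dimethylamino group or a carboxylic acid on a longer chain, and whether any of them would move the number beyond the scatter. They also leave open whether 4-methylpiperazin-1-yl together with 4-chloro-3-(trifluoromethyl)phenyl would give a number within the scatter of compound 3.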